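Swapping One Aromatic Ring on a Receptor Antagonist Core

This account rests on a few compounds, and the source may have more. Where it says the series, first, only, none or still open, it means among the compounds named here.

Compound 1 `COc1ccc(OC)c(-c2nc(C(c3ccccc3)c3ccccc3)sc2CC(=O)O)c1` was measured in an in vitro functional assay on HEK285-7 cells for antagonist activity at prostaglandin D2 receptor 2 (Homo sapiens), read by BRET and beta-arrestin recruitment (a lower number here means a smaller maximal response, a higher number a larger maximal response), and there compound 1 gives 80%. A second compound, compound 2 `Cc1cc(-c2nc(C(c3ccc(F)cc3)c3ccc(F)cc3)sc2CC(=O)O)ccn1`, carries another aromatic ring on the shared core and different substituents on the large group, and in this assay compound 2 gives 80%. The two values are level at the digits shown, so compound 1 stands with compound 2 inside the usual scatter, and no ordering between them can be drawn.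

Compound 3 `O=C(O)Cc1sc(C(c2ccccc2)c2ccccc2)nc1-c1ccc(F)cc1` has not yet been measured. Among the measured compounds shown here, the single difference from compound 1 is 4-fluorophenyl in place of 2,5-dimethoxyphenyl on an aromatic carbon. For the measured compounds named here, no step between measured compounds that differ in one place is available, so any expectation rests on the two values above. Because compound 2 gives 80% with a different aromatic ring at that position, the ring there appears tolerated for the maximal response.

The step from compound 1 to compound 3 is expected to be no change at the digits printed from compound 1 to compound 3 (within the scatter), none beyond the scatter. Compound 3 is therefore estimated to give 80% in this assay, within 65% to 95%.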

Compound 3, largest response reached (reported as efficacy), in percent of the reference or control that the assay uses: 80%
Compound 3: middle estimate and measured number agree at the digits printed; the range from low to high includes it.
By their numbers in this assay, from the lowest: compounds 1, 2 and 3 (each within the scatter of the next).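

Placing 4-fluorophenyl where 2,5-dimethoxyphenyl stood in this assay gives no change at the digits printed from compound 1 to compound 3 (within the scatter), and this is the first comparison at this position in which nothing else on the molecule differs. Compound 1 and compound 2 differ in more than one place, so their level values could not separate the ring from the rest; this pair can. The entering ring has fewer heavy atoms than the leaving group and 0 hydrogen-bond acceptors against 2, so for this pair neither the two oxygens nor the larger size of the leaving group is needed to keep the maximal response, though no measurement shown here gives a reason for this.

From the compounds shown here alone, how far this tolerance extends remains open: a ring carrying an amine, a saturated cyclohexyl ring or a single methyl group at this position could behave quite differently. Going by these compounds, the role of the two fluorines on the large group of compound 2 also stays open, as that compound differs from compound 1 at both sites at once.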